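Sulfonyl-cyclopentane and sulfonyl-pyrrolidine nitriles: one aryl swap

The source may hold more compounds than are shown below. What is called first, only, known or untested is meant among the compounds shown, and "the series" means these compounds.

Measured so far:
- compound 1, `N#CCNC(=O)[C@@H]1C[C@@H](S(=O)(=O)c2ccccc2Cl)C[C@H]1C(=O)N1CCOCC1`: 3 nM
- compound 2, `N#CCNC(=O)[C@@H]1C[C@@H](S(=O)(=O)c2ccccc2C(F)(F)F)C[C@H]1C(=O)N1CCOCC1`: 2 nM
- compound 3, `N#CCNC(=O)[C@@H]1CN(S(=O)(=O)c2ccccc2Cl)C[C@H]1C(=O)N1CCOCC1`: 208 nM

Compounds 1 and 2 share one core; compound 3 and the unmeasured compound 4, `N#CCNC(=O)[C@@H]1CN(S(=O)(=O)c2ccccc2C(F)(F)F)C[C@H]1C(=O)N1CCOCC1`, share another. How the core of compound 1 differs from that of compound 3 is not broken down here; in a functional assay on A20 cells (Mus musculus) for inhibition, with stated times of 1 h, 16 h and 24 h (a lower number here means a stronger inhibitor, a higher number a weaker inhibitor), compound 3 gives 208 nM, while compound 1 gives 3 nM, a gap given as beyond the scatter.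

The change trifluoromethyl in place of chloro on an aromatic carbon made the step of a 1.5-fold lower number from compound 1 to compound 2 (0.18 log units; within the scatter). The change trifluoromethyl in place of chloro on an aromatic carbon is the same change on the second core. Because that step a 1.5-fold lower number from compound 1 to compound 2 (0.18 log units; within the scatter) stayed within the scatter, compound 4 is expected to show a step of about a 1.4-fold lower number from compound 3 to compound 4 (0.14 log units; within the scatter) in this assay. Compound 4 is therefore estimated at 150 nM in this assay, with a range of 60 nM to 400 nM.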

Compound 4, half-maximal inhibitory concentration: 118 nM
Compound 4: middle estimate off by 1.3-fold (0.10 log units), on the high side; the range from low to high includes it.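

In this assay, trifluoromethyl in place of chloro on an aromatic carbon gives a 1.8-fold lower number from compound 3 to compound 4 (0.25 log units; within the scatter), and the same change on the two cores agrees: the same change on two cores in this assay, a 1.5-fold lower number (0.18 log units; within the scatter) from compound 1 to compound 2 and a 1.8-fold lower number (0.25 log units; within the scatter) from compound 3 to compound 4, 1.2-fold (0.07 log units) apart, within the scatter of two such steps. For these two cores, the change therefore carries across as a step within the scatter, and neither core gives it a separate size. This does not show that the agreement extends to any other core, nor does it separate trifluoromethyl from chloro on either core.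

The compounds shown carry only chloro and trifluoromethyl on the aromatic ring. On these data alone, it remains open whether a methoxy group, an amine or a carboxylic acid there would give matching steps on both cores.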